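This account rests on a few compounds, and the source may have more. Where it says the series, first, only, none or still open, it means among the compounds named here.

Compound 1, `COc1ccc2c(c1)CC(CCN(C)C)=C2C(C)c1ccccn1`, with 6030 nM in an assay on CHO-K1 cells for binding affinity to muscarinic acetylcholine receptor M5 (Homo sapiens); a higher number here means a weaker inhibitor, a lower number a stronger inhibitor.
Compound 2, `CC(C1=C(CCN(C)C)Cc2cc(Cl)ccc21)c1ccccn1`, with 724 nM in this assay.
Compound 3, `CCN(CC)CCC1=C(C(C)c2ccccn2)c2ccccc2C1`, with 2090 nM in this assay.

Among these three numbers compound 3 stands second highest: compound 1 lies higher and compound 2 lower, and both gaps are beyond the usual scatter. Compound 4, `CC(C1=C(CN(C)C(C)C)Cc2ccccc21)c1ccccn1`, has not yet been measured. It differs from compound 3 in one place: isopropyl(methyl)amino in place of (diethylamino)methyl on a saturated chain carbon bound to a double-bonded ring carbon. The change shortens the chain that carries the amine and alters the groups on that nitrogen, while the rest of the shared core stays as in compound 3.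

For the measured compounds named here, only one single-place step is known here, an 8.3-fold lower number from compound 1 to compound 2 (0.92 log units; beyond the scatter), and it concerns a group on the aromatic ring, not the amine chain, so it says nothing direct about this change. Compound 2 and compound 3 differ in two places at once, so their values cannot be split into parts. Going by the values given here, with no comparable step to lean on, the expectation for this assay is a change no larger than the scatter in either direction, with wide uncertainty. Compound 4 is therefore estimated at 2000 nM, between 700 nM and 6000 nM, which means an expected step of a 1.0-fold lower number from compound 3 to compound 4 (0.02 log units; within the scatter).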

Compound 4, inhibition constant: 1120 nM
Compound 4: the middle estimate sits 1.8-fold (0.25 log units) above what was measured; the range from low to high includes it.
By their numbers in this assay, from the lowest: compounds 2, 4 and 3 (each within the scatter of the next, the first and the last beyond it); then compound 1.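

Swapping the 2-(diethylamino)ethyl group for (isopropyl(methyl)amino)methyl in this assay gives a 1.9-fold lower number from compound 3 to compound 4 (0.27 log units; within the scatter) and so shows that, across compound 3 and compound 4, this position accepts a shorter amine-carrying chain with different groups on the nitrogen without a change that can be told from the scatter. For the compounds shown here, this is the first single-place step at the amine chain, whereas the earlier step of an 8.3-fold lower number from compound 1 to compound 2 (0.92 log units; beyond the scatter) lay on the aromatic ring and says nothing about this position. Nothing shown offers a measured explanation for this result.

Chain length and the groups on the nitrogen changed together in this one step, so it remains open how each acts alone, which a compound with isopropyl(methyl)amino on the longer chain of compound 3, or with a pyrrolidine ring in place of the open amine, could help to separate. As far as these compounds go, it also remains open whether the chloro group carried by compound 2 would have any comparable effect on the core of compound 4.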